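The source may hold more compounds than are shown below. What is called first, only, known or untested is meant among the compounds shown, and "the series" means these compounds.

The read-out throughout is a functional assay on the whole organism for inhibition, with Rattus norvegicus as the target, with a stated time of 30 min, at a dose of 1 mg/kg by the intravenous route; on this read-out higher numbers stand for more inhibition at the one dose given (going by the name of the read-out) and lower numbers for less inhibition. Compound 1 `O=C(Cl)c1ccc2occc(=O)c2c1` gave "nd(insoluble)" (no result reported) in this assay, so no number exists for it. Compound 2 `O=C(O)CCCCCNC(=O)c1cc(=O)c2ccccc2o1` gives 0% in this assay, and compound 3 `O=C(O)CCNC(=O)c1cc(=O)c2ccccc2o1` gives 0%. For the measured compounds named here, the only single-place step among the measured compounds, no change at the digits printed from compound 2 to compound 3 (within the scatter), was carboxy in place of 3-carboxypropyl on a saturated chain carbon, two bonds along the chain from an amide-type nitrogen, and it moved the read-out by nothing beyond the scatter. Compound 3 therefore stands level with compound 2, its nearest neighbour, at the foot of the scale, with compound 1 contributing no number.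

Compound 4 `Cn1nnc(NC(=O)c2cc(=O)c3ccccc3o2)n1` has not yet been measured in this assay. It differs from compound 3 as follows: 2-methyl-2H-tetrazol-5-yl in place of 2-carboxyethyl on an amide-type nitrogen. Going by the values given here, no measured step touches the amide nitrogen itself; the one step that is known altered only the chain and showed no change. Both measured amides gave no inhibition, and nothing among them points to a rise. The change in compound 4 is of a different kind from the measured step, so the upper side of the range is left open. The expected step of a number 5 percentage points higher from compound 3 to compound 4 (within the scatter) is small. Compound 4 is expected to give 5%, between 0% and 30%.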

Compound 4, a percentage reported as inhibition, in the whole organism at one dose (the size of the read-out at that dose, not a potency): 25%
Estimate against measurement, compound 4: 20 percentage points below, and the stated range covers the measured number.
By their numbers in this assay, from the lowest: compounds 2 and 3 (each within the scatter of the next); then compound 4.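

With a number 25 percentage points higher from compound 3 to compound 4 (beyond the scatter), the amide nitrogen emerges as a place where the read-out in this assay can rise, something the earlier chain change, no change at the digits printed from compound 2 to compound 3 (within the scatter), gave no sign of. The change here is of a different kind from that one: 2-carboxyethyl, which has no ring, leaves, and 2-methyl-2H-tetrazol-5-yl, a five-membered aromatic ring with 4 hetero atoms, enters on the amide-type nitrogen, and among the compounds with a number only compound 4, at 25%, stands clear of the foot of the scale. No measurement shown bears on why this replacement raises the inhibition.

Because the step exchanges the whole substituent at once, it cannot separate the loss of the carboxylic acid from the arrival of the ring or from the methyl group on that ring. On these data alone, whether the rise stays with an unsubstituted tetrazol-5-yl group, passes to a phenyl ring or a pyridine ring on the same nitrogen, or extends to doses other than the single one given remains open.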